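Working notes on compound 4 following from compound 2

This account rests on a few compounds, and the source may have more. Where it says the series, first, only, none or still open, it means among the compounds named here.

Measured so far in a functional assay on the whole organism with Rattus norvegicus as the target, at a dose of 100 mg/kg; a lower number here means less inhibition, a higher number more inhibition at the dose given (going by the name of the read-out):
compound 1 `O=c1ccc(-c2ccccc2)nn1CCCNC(=S)Nc1ccccc1`: 12.1%
compound 2 `N#CNC(=N)NCCCCCn1nc(-c2ccccc2)ccc1=O`: 31%
compound 3 `C/N=C(/NC#N)NCCCCn1nc(N2CCCC2)ccc1=O`: -1%

Compound 2 stands highest of the three numbers. The nearest is compound 1, whose read-out lies below that of compound 2 by a gap beyond the usual scatter; compound 3 lies furthest below, also beyond the scatter. For the measured compounds named here, no two of the measured compounds differ in a single place, so no single-change step has been measured.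

Compound 4 `C/N=C(/NC#N)NCCCCCn1nc(-c2ccccc2)ccc1=O` is the next compound to be measured. It differs from compound 2 as follows: a group of 6 heavy atoms (3 carbon, 3 nitrogen; no ring) in place of a group of 5 heavy atoms (2 carbon, 3 nitrogen; no ring), on an amine nitrogen. The entering group has 3 carbon where the leaving group has 2, and 1 hydrogen-bond donor where the leaving group has 2. Compound 3 also carries this entering group, but on a different chain and with a different substituent on the core, so its value of -1% does not isolate this change.

Given the modest size of the change, the step from compound 2 to compound 4 is expected to be small, at most a slight fall, and plausibly none beyond the scatter. For compound 4 the estimate in this assay is 23%, with a range from 5% to 40%, which corresponds to an expected step of a number 8 percentage points lower from compound 2 to compound 4 (within the scatter).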

Compound 4, a percentage reported as inhibition, in the whole organism at one dose (the size of the read-out at that dose, not a potency): 47.6%
For compound 4 the middle estimate is 24.6 percentage points below the measured one; measured number above the stated range.
By their numbers in this assay, from the lowest: compound 3; then compound 1; then compound 2; then compound 4.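

In this assay, for the compounds shown here, the exchange on an amine nitrogen whose other neighbours are saturated chain carbon gives the first single-place step, a number 16.6 percentage points higher from compound 2 to compound 4 (beyond the scatter), with the rest of the structure unchanged. At this position, going from 5 to 6 heavy atoms and from 2 hydrogen-bond donors to 1 therefore raises the inhibition at this dose on the shared core of the two compounds, rather than leaving it flat or lowering it. Nothing at hand explains the rise.

The compounds shown leave open whether the step carries over to other chains or cores, since compound 3 carries the same entering group but differs from compound 4 in more than one place, and its value in this assay therefore cannot be read against this change. They also leave open how the read-out responds to an ethyl group in the same place on the entering group, or to a longer chain, and, with only a single dose reported, how compound 4 would behave at other doses.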